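The source may report more compounds than this note shows. Statements on the series, on what has been measured and on what is new or still open speak of the compounds shown alone.

Of the compounds shown here, two have numbers so far. Compound 1 `CCCC(=O)c1c(C)nn(CCCN2CCN(c3ccc(C)cc3)CC2)c(=O)c1N` gives 25% in a functional assay on the whole organism (Abdomen, strain Swiss) for inhibition, with Mus musculus as the target, with stated times of 30 min, 10 min and 5 min, at a dose of 20 mg/kg by the oral route (on this read-out higher numbers stand for a stronger effect at the one dose given and lower numbers for a weaker effect), which is the higher of the two. Compound 2 `C=Cc1c(CC)nn(CCCN2CCN(c3ccc(C)cc3)CC2)c(=O)c1N` gives 0% in this assay, a gap that lies beyond the usual scatter of repeated measurements; compound 2 carries a vinyl group and an ethyl group where compound 1 has a propylcarbonyl and a methyl group, so the two differ in more than one place and no single step can be read from them.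

Compound 3 `CC/C=C/c1c(C)nn(CCCN2CCN(c3ccc(C)cc3)CC2)c(=O)c1N` has not yet been measured. It is compound 1 with one change: but-1-en-1-yl in place of propylcarbonyl on an aromatic carbon. Going by the values given here, no measured pair shows this exchange, so the size of the step is uncertain. Since compound 2, which likewise lacks the carbonyl, gives 0%, a downward step is expected, estimated as a number 15 percentage points lower from compound 1 to compound 3 (beyond the scatter). Compound 3 is expected to give about 10%, within a range from 0% to 30%.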

Compound 3, a percentage reported as inhibition, in the whole organism at one dose (the size of the read-out at that dose, not a potency): 35%
Compound 3: middle estimate off by 25 percentage points, on the low side; the measured number lies above the stated range.
By their numbers in this assay, from the lowest: compound 2; then compounds 1 and 3 (each within the scatter of the next).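

In this assay, placing but-1-en-1-yl in place of propylcarbonyl on this aromatic carbon, opposite the ring nitrogen, gives a number 10 percentage points higher from compound 1 to compound 3 (within the scatter). At this position, then, the carbonyl and its hydrogen-bond acceptor can be exchanged for a carbon-only group of similar size without a step beyond the scatter, at least in this one pair. Nothing available here explains why the two groups give values within the scatter of each other.

As far as these compounds go, whether this tolerance extends to a saturated butyl chain, an amine or a carboxylic acid at the same position remains open. These values also describe the size of the effect at a single dose, so they leave the relative potency of compound 1 and compound 3 unresolved.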